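Methoxy for Methyl on a Second Core

The source may hold more compounds than are shown below. What is called first, only, known or untested is meant among the compounds shown, and "the series" means these compounds.

Measured in a functional assay on HCT-116 cells (Homo sapiens) for cytotoxicity, read by MTT assay, with a stated time of 72 h; a lower number here means a stronger inhibitor, a higher number a weaker inhibitor:
Compound 1 `COc1ccc(/C=C2\S/C(=N\c3csc(-c4ccc(Cl)cc4)c3)NC2=O)cc1` gives 1300 nM.
Compound 2 `Cc1ccc(/C=C2\S/C(=N\c3csc(-c4ccc(Cl)cc4)c3)NC2=O)cc1` gives 1000 nM.
Compound 3 `COc1cccc(N2C(=O)CS/C2=N\c2csc(-c3ccc(C)cc3)c2)c1` gives 41000 nM.

Compounds 1 and 2 share one core and differ only by methoxy in place of methyl on an aromatic carbon; that change gave a 1.3-fold higher number from compound 2 to compound 1 (0.11 log units; within the scatter). Compound 3 is built on a different core, and the difference between the two cores is not broken down here; its number is far higher than that of compound 1 or compound 2.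

Compound 4 `COc1ccc(-c2cc(/N=C3\SCC(=O)N3c3cccc(OC)c3)cs2)cc1` has not been measured. It is obtained from compound 3 by methoxy in place of methyl on an aromatic carbon, the same change that turned compound 2 into compound 1. In this assay compound 4 is expected to give 45000 nM, most likely between 20000 nM and 100000 nM. That estimate means a step of a 1.1-fold higher number from compound 3 to compound 4 (0.04 log units; within the scatter), expected to be small because the same change earlier gave a 1.3-fold higher number from compound 2 to compound 1 (0.11 log units; within the scatter).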

Compound 4, half-maximal inhibitory concentration: 2700 nM
For compound 4 the middle estimate is 17-fold (1.22 log units) above the measured one; the measured number lies below the stated range.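

In this assay, the change from 4-methylphenyl to 4-methoxyphenyl gave a 15-fold lower number from compound 3 to compound 4 (1.18 log units; beyond the scatter), a large step that stands apart from the earlier one on the core of compound 1 and compound 2: the same change on two cores in this assay, a 1.3-fold higher number (0.11 log units; within the scatter) from compound 2 to compound 1 and a 15-fold lower number (1.18 log units; beyond the scatter) from compound 3 to compound 4, 20-fold (1.30 log units) apart, beyond the scatter of two such steps

So in this series, the size of this change on one core did not predict its size on the other. Going by these compounds alone, this does not show why the two cores respond differently, and each core offers only a single pair of compounds.

On these data alone, it remains open how either core would respond if an amine, a carboxylic acid or a longer chain such as ethoxy stood in place of the methyl. Further pairs on each core would also be needed to show how general the gap is.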